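Replacing nitro with hydroxy on compound 1

This account rests on a few compounds, and the source may have more. Where it says the series, first, only, none or still open, it means among the compounds named here.

In a toxicity assay on cells (Erythrocyte, Mus musculus) for activation, read by spectrophotometry and hemolysis, with a stated time of 30 min (a lower number here means that less compound is needed, a higher number that more compound is needed for the effect), compound 1 (`O=[N+]([O-])c1ccc(O)c(/C=N/Nc2nc3ccccc3s2)c1`) gives > 200 ug/mL as a limit of the assay, not a number. Compound 2 (`Clc1ccc(/C=N/Nc2nc3ccccc3s2)cc1`) gives > 200 ug/mL as a limit too. So compound 1 stands at the limit of > 200 ug/mL in this assay, at which 3 of the 3 values shown sit, in this small set. Compound 4 (`Oc1ccc(O)c(/C=N/Nc2nc3ccccc3s2)c1`) differs from compound 1 by one change (hydroxy in place of nitro on an aromatic carbon): hydroxy in place of nitro on an aromatic carbon. Within the data shown here, no measured pair shows this step directly. Compound 3 (`Oc1cccc(/C=N/Nc2nc3ccccc3s2)c1O`) also carries hydroxy groups and gives > 200 ug/mL as a limit. On that ground, no shift beyond the scatter is expected in this assay, and the estimated step that the limit leaves unreadable from compound 1 to compound 4 is expected to stay within it. For compound 4 the estimated value is 250 ug/mL with a range from 100 ug/mL to 400 ug/mL and another limit is likely.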

Compound 4, half-maximal effective concentration: > 200 ug/mL
Compound 4: no number, only a limit (the forecaster's own chance of this, stated with the estimate: 85%); the middle value lies beyond the limit too.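

In this assay, compound 1 and compound 4 each give only a limit, not a number, so the step between them cannot be read. The compounds shown leave open whether any of these structural changes alters the concentration needed for the effect, since all of them rest at one limit: the limit of > 200 ug/mL in this assay, at which 4 of the 4 values shown sit.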